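This account rests on a few compounds, and the source may have more. Where it says the series, first, only, none or still open, it means among the compounds named here.

Measured compounds in an assay on a protein complex for inhibition of ubiquitin carboxyl-terminal hydrolase 1/WD repeat-containing protein 48 (Homo sapiens), read by fluorescence; on this read-out higher numbers stand for weaker inhibition and lower numbers for stronger inhibition:
- compound 1 `Cc1ccc(CNc2nc(-c3ccccc3C(F)(F)F)nc3ccccc23)s1`: 5100 nM
- compound 2 `FC(F)(F)c1ccccc1-c1nc(NCc2ccccc2)c2ccccc2n1`: 3100 nM
- compound 3 `FC(F)(F)c1ccccc1-c1nc(NCc2ccc(Cl)cc2)c2ccccc2n1`: 4800 nM

Compound 2 gives the lowest of the three numbers, but its distance to each neighbour is small: a 1.5-fold higher number from compound 2 to compound 3 (0.19 log units; within the scatter) and a 1.6-fold lower number from compound 1 to compound 2 (0.22 log units; within the scatter) both sit within the scatter, so no order among the three can be claimed. The unmeasured compound 4 `FC(F)(F)c1ccc(CNc2nc(-c3ccccc3C(F)(F)F)nc3ccccc23)cc1` differs from compound 2 by trifluoromethyl in place of hydrogen on an aromatic carbon. Among the compounds with values here, the measured step closest in kind is the one from compound 2 to compound 3, where a chloro group entered the same kind of position and gave a 1.5-fold higher number from compound 2 to compound 3 (0.19 log units; within the scatter). The other two steps, a 1.6-fold lower number from compound 1 to compound 2 (0.22 log units; within the scatter) and a 1.1-fold lower number from compound 1 to compound 3 (0.03 log units; within the scatter), show that swapping the whole aryl group on that chain carbon also moved the number little. For the step from compound 2 to compound 4 in this assay a shift of a 1.3-fold higher number from compound 2 to compound 4 (0.11 log units; within the scatter) is therefore expected, which would stay within the scatter, possibly toward a slightly higher number as with compound 3. Compound 4 is thus estimated at 4000 nM, with a range of 2000 nM to 8000 nM.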

Compound 4, half-maximal inhibitory concentration: 8900 nM
The estimate for compound 4 lay 2.2-fold (0.35 log units) below the measured number; measured number outside the range, above it.
By their numbers in this assay, from the lowest: compounds 2, 3, 1 and 4 (each within the scatter of the next, the first and the last beyond it).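

In this assay, within the data shown here, trifluoromethyl on the aromatic carbon para to a large group produced the first step to lie beyond the scatter (a 2.9-fold higher number from compound 2 to compound 4 (0.46 log units; beyond the scatter)), a modest one. Among these compounds, measured against other groups, the same compound stayed within the scatter, both where trifluoromethyl replaced chloro at this position (a 1.9-fold higher number from compound 3 to compound 4 (0.27 log units; within the scatter)) and where 4-(trifluoromethyl)phenyl replaced 5-methylthiophen-2-yl (a 1.7-fold higher number from compound 1 to compound 4 (0.24 log units; within the scatter)), so only the pair with the unsubstituted phenyl is separated. No available evidence bears on the origin of this step.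

The compounds shown leave open what an amine, a carboxylic acid or a methoxy group on this same carbon would do in this assay. They also leave open whether trifluoromethyl on another carbon of this ring would give a similar step.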